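Working notes: from E to Z at the double bond

The source may hold more compounds than are shown below. What is called first, only, known or untested is meant among the compounds shown, and "the series" means these compounds.

Compound 1 `COc1ccc(/C(F)=C(/Br)c2cc(OC)c(OC)c(OC)c2)cc1O` | > 200000 nM (limit)
Compound 2 `COc1cc(/C=C/c2cc(O)c3ccoc3c2)cc(OC)c1OC` | 27000 nM

Going by the values given here, in a functional assay on cells (Endothelial cell, Bos taurus) for antiproliferative activity (a higher number here means a weaker inhibitor, a lower number a stronger inhibitor), compound 2 gives 27000 nM as the only actual number so far. Compound 1 gives > 200000 nM which is a limit of the assay and not a number. Compound 2 therefore has no second number to be ranked against.

The next compound is compound 3 `COc1cc(/C=C\c2cc(O)c3ccoc3c2)cc(OC)c1OC` and its relation to compound 2 is simple: the two compounds have the same atoms and bonds and differ only in configuration as drawn: 1 of 1 stereo elements differ; a double bond is drawn E in compound 2 and Z in compound 3 with no other change. Among the compounds with values here, no measured pair shows what this kind of change does, so what follows is an expectation only. The step of a 54-fold lower number from compound 2 to compound 3 (1.73 log units; beyond the scatter) is expected to be large, well beyond the scatter and towards a stronger inhibitor. For compound 3 the estimated value is 500 nM with an expected range from 20 nM to 10000 nM in this assay.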

Compound 3, half-maximal inhibitory concentration: 49 nM
Estimate against measurement, compound 3: 10-fold (1.01 log units) above, within the range that was stated.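

In this assay the series now has its first measured pair, and the change at the double bond is a 550-fold lower number from compound 2 to compound 3 (2.74 log units; beyond the scatter), towards a stronger inhibitor with the Z drawing. The step can be assigned to the configuration at this double bond alone because of one fact: the fact that compounds 2 and 3 differ only in the configuration as drawn. The earlier compounds shown here offered a single number and no step, so they gave no size for this change.

Going by these compounds, whether the Z drawing keeps its advantage when the hydroxyl group gives way to an amine or a carboxylic acid stays open, since this pair carries one substituent pattern only. Compound 1 gives > 200000 nM, a limit of the assay and not a number, and it differs from this pair in more than one place, so it settles nothing here.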